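Working notes: the step from compound 3 to compound 4

This account rests on a few compounds, and the source may have more. Where it says the series, first, only, none or still open, it means among the compounds named here.

In a functional assay on B16 cells (Mus musculus) for inhibition (a lower number here means a stronger inhibitor, a higher number a weaker inhibitor), compound 1 (`CC(C)CN(CC(=O)N(CC(C)C)NC(=O)OCc1ccccc1)NC(=O)CBr`) gives 1300 nM as the lowest number of the three. Compound 2 (`CC(C)CN(CC(=O)N(CC(C)C)NC(=O)OCc1ccccc1)/N=C/c1ccccc1B(O)O`) gives 26300 nM and compound 3 (`CC(C)CN(CC(=O)N(CC(C)C)NC(=O)OCc1ccccc1)/N=C/c1cccc(B(O)O)c1`) gives 53900 nM as the highest number. Compound 4 (`CC(C)CN(NC(=O)OCc1ccccc1)C(=O)CN(Cc1cccnc1)/N=C/c1cccc(B(O)O)c1`) differs from compound 3 by pyridin-3-yl in place of isopropyl on a saturated chain carbon bound to an amine nitrogen in one place: pyridin-3-yl in place of isopropyl on a saturated chain carbon bound to an amine nitrogen. The large steps of a 20-fold higher number from compound 1 to compound 2 (1.31 log units; beyond the scatter) and a 41-fold higher number from compound 1 to compound 3 (1.62 log units; beyond the scatter) and the modest step of a 2.0-fold higher number from compound 2 to compound 3 (0.31 log units; beyond the scatter) all lie elsewhere in the structure, and none bears directly on this change. No step beyond the scatter is therefore expected in this assay and no direction can be assigned with confidence. The expected step is a 1.3-fold lower number from compound 3 to compound 4 (0.13 log units; within the scatter) and stays within the scatter. For compound 4 the estimated value is 40000 nM with an expected range from 13000 nM to 110000 nM in this series.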

Compound 4, half-maximal inhibitory concentration: 74900 nM
Compound 4: the middle estimate sits 1.9-fold (0.27 log units) below what was measured; the measured number falls inside the stated range.
By their numbers in this assay, from the lowest: compound 1; then compound 2; then compounds 3 and 4 (each within the scatter of the next).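

In this assay the change gives a 1.4-fold higher number from compound 3 to compound 4 (0.14 log units; within the scatter), so pyridin-3-yl in place of isopropyl on a saturated chain carbon bound to an amine nitrogen leaves the number within the scatter. Compounds 1, 2 and 3 all carry isopropyl here and could not show this; the series now has one reading at this position, in a weak compound. Nothing shown explains the result.

Going by these compounds, it remains open whether the same change would hold with the bromine-bearing group of compound 1. On these data alone, what a primary amine or a carboxylic acid would give at this position also remains open.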